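Halogenated phenyl replaces dimethoxyphenyl on a bile acid receptor series

The compounds below may be only part of what the source reports. "The series", "measured", "known", "first", "only" and "open" are said of these compounds alone.

Compound 1 `COC(=O)/C=C/c1cccc(N(Cc2ccc(-c3ccc(SC)cc3)cc2)C(=O)C(C)C)c1`: in an assay on isolated protein with Bile acid receptor (Homo sapiens) as the target (on this read-out lower numbers stand for an effect already at smaller amounts and higher numbers for an effect only at larger amounts of compound), compound 1 gives 51 nM.
Compound 2 `COC(=O)/C=C/c1cccc(N(Cc2ccc(-c3c(OC)cccc3OC)cc2)C(=O)C(C)C)c1`: in this assay compound 2 gives 95 nM.

Of the compounds shown here, two have been measured so far, and the only step between them, a 1.9-fold higher number from compound 1 to compound 2 (0.27 log units; within the scatter), does not reach beyond the scatter, so the numbers for compound 1 and compound 2 are read as equivalent. Compound 3 `COC(=O)/C=C/c1cccc(N(Cc2ccc(-c3ccc(F)c(Cl)c3)cc2)C(=O)C(C)C)c1` is not yet measured. It differs from compound 2 in one place: 3-chloro-4-fluorophenyl in place of 2,6-dimethoxyphenyl on an aromatic carbon. Among the compounds with values here, the single measured step bears only loosely on this change, since it swapped one substituted phenyl for another without moving the number beyond the scatter; a third substituted phenyl in the same place is therefore expected to behave similarly, with no basis in the data for a shift in either direction beyond the scatter. The expected step is a 1.6-fold lower number from compound 2 to compound 3 (0.20 log units; within the scatter). On that basis compound 3 is estimated at 60 nM, with a range from 25 nM to 150 nM.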

Compound 3, half-maximal effective concentration: 129 nM
The estimate for compound 3 lay 2.2-fold (0.33 log units) below the measured number, and the stated range covers the measured number.
By their numbers in this assay, from the lowest: compounds 1, 2 and 3 (each within the scatter of the next, the first and the last beyond it).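

In this assay, the step of a 1.4-fold higher number from compound 2 to compound 3 (0.13 log units; within the scatter) shows that this position takes 3-chloro-4-fluorophenyl in place of 2,6-dimethoxyphenyl without a change beyond the scatter, even though the entering group has 0 hydrogen-bond acceptors and the leaving group has 2. Within the data shown here, the other new step, a 2.5-fold higher number from compound 1 to compound 3 (0.40 log units; beyond the scatter), is modest but is the first to lie beyond the scatter, so the choice of substituted phenyl at this place is not wholly without consequence, although compound 2 remains within the scatter of both compound 1 and compound 3. No experimental information is available to explain these differences.

The chlorine and the fluorine enter together, so the compounds shown do not separate the contribution of each to the step from compound 1 to compound 3. They also leave open whether a phenyl ring carrying an amine or a carboxylic acid at this place would stay in the same range of numbers.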